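The source may hold more compounds than are shown below. What is called first, only, known or untested is meant among the compounds shown, and "the series" means these compounds.

Three carbamates sharing one core have been measured. Compound 1 `N#C[Se]c1ccc(NC(=O)Oc2ccc(F)cc2)cc1` gives 19800 nM in an ADME assay on BEAS-2B cells (Homo sapiens) for cytotoxicity, read by MTT assay, with a stated time of 72 h; on this read-out lower numbers stand for stronger inhibition of growth and higher numbers for weaker inhibition of growth. Compound 2 `CCCOC(=O)Nc1ccc([Se]C#N)cc1` gives 19200 nM in this assay, and compound 3 `Cc1ccc(OC(=O)Nc2ccc([Se]C#N)cc2)cc1` gives 5600 nM in this assay. Within the data shown here, the one single-point step among them, a 3.5-fold lower number from compound 1 to compound 3 (0.55 log units; beyond the scatter), changes a substituent on an aromatic carbon rather than the chain.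

Compound 2 stands second highest of the three numbers: its value and that of compound 1 lie within the usual scatter of each other, so nothing separates them, while compound 3 sits beyond the scatter with the lower number.

The next compound, compound 4 `CCCCOC(=O)Nc1ccc([Se]C#N)cc1`, differs from compound 2 in one place: methyl in place of hydrogen on a saturated chain carbon, three bonds along the chain from an oxygen next to a carbonyl group. Among the measured compounds shown here, no measured step concerns the carbamate chain, so the step from compound 1 to compound 3 offers no direct guide, and there is nothing among the measured values to suggest that one added chain carbon should move the number beyond the scatter. On that basis the step from compound 2 to compound 4 in this assay is expected to be small, within the scatter, with no direction favoured; the expected step is a 1.2-fold lower number from compound 2 to compound 4 (0.08 log units; within the scatter). Compound 4 is therefore estimated at 16000 nM, within the range 6000 nM to 40000 nM.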

Compound 4, concentration for 50% growth inhibition: 5000 nM
Beside the measured number, compound 4's estimate is 3.2-fold (0.51 log units) above it; the measured number lies below the stated range.
By their numbers in this assay, from the lowest: compounds 4 and 3 (each within the scatter of the next); then compounds 2 and 1 (each within the scatter of the next).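

In this assay, the carbamate chain proves to be a place where a small change registers: methyl in place of hydrogen on a saturated chain carbon, three bonds along the chain from an oxygen next to a carbonyl group, gives a 3.8-fold lower number from compound 2 to compound 4 (0.58 log units; beyond the scatter). Among these compounds, the earlier compounds could not show this, as their only step, a 3.5-fold lower number from compound 1 to compound 3 (0.55 log units; beyond the scatter), changes a substituent on an aromatic carbon and leaves the chain out of the comparison. Nothing available here accounts for the effect of going from propyl to butyl on this read-out.

With one step along the chain, the compounds shown cannot tell whether the number keeps falling with a longer chain such as pentyl or hexyl, or whether butyl marks a turning point. They also leave open whether a branched chain, or a chain ending in an amine or a carboxylic acid, would keep the effect, and whether the same step would hold in any other cell line.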